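The compounds below may be only part of what the source reports. "The series", "measured", "known", "first", "only" and "open" are said of these compounds alone.

Measured in an ADME assay on CRL8155 cells (Homo sapiens) for cytotoxicity, read by resazurin assay, with a stated time of 72 h; a higher number here means that more compound is needed for the effect, a lower number that less compound is needed:
- compound 1 `O=C(NCCCCO)Nc1nc2ccc(C(=O)c3ccccc3)cc2[nH]1`: > 30000 nM
- compound 2 `NCCCCCCC(=O)Nc1nc2ccc(C(=O)c3ccccc3)cc2[nH]1`: > 30000 nM
- compound 3 `O=C(CCC1CCNCC1)Nc1nc2ccc(C(=O)c3ccccc3)cc2[nH]1`: > 30000 nM

Compound 1 stands only at a limit, > 30000 nM, not at a number. The same holds for the whole set: the limit of > 30000 nM in this assay, at which 3 of the 3 values shown sit.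

The step of interest leads to compound 4 `O=C(CCCC1CCNCC1)Nc1nc2ccc(C(=O)c3ccccc3)cc2[nH]1`: 3-(piperidin-4-yl)propyl in place of (4-hydroxybutyl)amino on a carbonyl carbon. In words, 3-(piperidin-4-yl)propyl in place of (4-hydroxybutyl)amino on a carbonyl carbon.

Bearing on it are a step that the two limits leave unreadable from compound 1 to compound 3, a step that the two limits leave unreadable from compound 1 to compound 2 and a step that the two limits leave unreadable from compound 2 to compound 3. None of these has a size that can be read. No step beyond the scatter is therefore expected in this assay, and no direction is favoured. The expected outcome is a number no higher from compound 1 to compound 4 (the limit leaves the size open). Compound 4 is estimated at 30000 nM, with an expected range of 12000 nM to 60000 nM, and most likely will again report as a limit.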

Compound 4, half-maximal effective concentration: > 30000 nM
Compound 4 gave a limit, no number; the forecaster's own chance of this, stated with the estimate: 80%; the middle value sits exactly at the limit.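

In this assay, for the compounds shown here, compound 4 gives > 30000 nM, which is a limit, so no step to compound 4 from compound 1, compound 2 or compound 3 can be read. The compounds shown leave open whether any group on this carbonyl carbon gives a measurable number, with the series resting at one value: the limit of > 30000 nM in this assay, at which 4 of the 4 values shown sit.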